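The compounds below may be only part of what the source reports. "The series", "measured", "known", "first", "only" and "open" are said of these compounds alone.

Compound 1 `CN(C)c1nc2cc(Cl)c(Cl)cc2n1COC(CO)CO`: in a functional assay on KB cells (Homo sapiens) for inhibition (a higher number here means a weaker inhibitor, a lower number a stronger inhibitor), compound 1 reaches only a limit of the assay, > 100000 nM.
Compound 2 `OCC(CO)OCn1c(SCc2ccccc2)nc2cc(Cl)c(Cl)cc21`: in this assay compound 2 likewise stops at a limit, > 100000 nM.
Compound 3 `CN(C)c1nc2c(Cl)c(Cl)ccc2n1COC(CO)CO`: in this assay compound 3 also gives a limit, > 100000 nM.

Compound 1 and compound 3 are built from the same atoms joined differently; the difference between the two cores is not broken down here. The change from compound 1 to compound 2 is benzylsulfanyl in place of dimethylamino on an aromatic carbon. Its step, a step that the two limits leave unreadable from compound 1 to compound 2, cannot be sized, since both ends are limits. Compound 4 `OCC(CO)OCn1c(SCc2ccccc2)nc2c(Cl)c(Cl)ccc21`, not yet measured, carries the same change on the core of compound 3: benzylsulfanyl in place of dimethylamino on an aromatic carbon. Within the data shown here, all three measured values sit at the limit of > 100000 nM in this assay, at which 3 of the 3 values shown sit, so no step among them can be read. The step from compound 3 to compound 4 is expected to be a step that the limit leaves unreadable from compound 3 to compound 4, an expectation resting on compound 1 and compound 2 both sitting at a limit with a step that the two limits leave unreadable from compound 1 to compound 2 unreadable. Compound 4 is therefore expected to give 200000 nM in this assay, most probably again only a limit, with a range from 50000 nM to 1000000 nM.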

Compound 4, half-maximal inhibitory concentration: 60000 nM
Compound 4: the middle estimate sits 3.3-fold (0.52 log units) above what was measured, within the range that was stated.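

In this assay, benzylsulfanyl in place of dimethylamino on the core of compound 3 gives an at least 1.6-fold lower number from compound 3 to compound 4 (0.22 log units; that floor lies within the scatter), so the step is only a floor, and on its own it does not establish a real change. On the core of compound 1 the same change cannot be read, since both ends are limits, so the data neither confirm nor refute that the change carries from one core to the other. Compound 4 is the only one of the four compounds with a value that is a number, and the other three stop at one limit: the limit of > 100000 nM in this assay, at which 3 of the 4 values shown sit.

Still open, going by these compounds, is whether the step on the core of compound 3 reaches beyond the scatter, and whether the same change has any readable size on the core of compound 1. Also open, on these data alone, is how an amine, a carboxylic acid or a longer chain in place of benzylsulfanyl on that same aromatic carbon would read in this assay.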